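The source may hold more compounds than are shown below. What is called first, only, known or untested is meant among the compounds shown, and "the series" means these compounds.

Measured compounds:
- compound 1 `CCCn1c(=O)n(CCOC)c(=O)c2[nH]cnc21`; in an assay on Cerebral cortex for binding affinity to adenosine receptor A1 (Cavia porcellus), read by radioligand binding (a higher number here means a weaker inhibitor, a lower number a stronger inhibitor), compound 1 gives 2500 nM
- compound 2 `CCCn1c(=O)n(CCOCC)c(=O)c2[nH]cnc21`; compound 2 gives 1900 nM
- compound 3 `CCCn1c(=O)n(C)c(=O)c2c1ncn2CCOC`; compound 3 gives 12400 nM

Compounds 1 and 2 share one core; compound 3 carries another, and the difference between the two cores is not broken down here. Compound 3 stands at the highest number of the three, beyond the scatter against both others. Compound 2 differs from compound 1 by methyl in place of hydrogen on a saturated chain carbon bound to an oxygen on a saturated carbon; that step is a 1.3-fold lower number from compound 1 to compound 2 (0.12 log units; within the scatter).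

Compound 4 `CCCn1c(=O)n(C)c(=O)c2c1ncn2CCOCC` has not yet been measured. It differs from compound 3 by methyl in place of hydrogen on a saturated chain carbon bound to an oxygen on a saturated carbon, the same change at the same place on the other core. The expected step is a 1.3-fold lower number from compound 3 to compound 4 (0.12 log units; within the scatter), because a 1.3-fold lower number from compound 1 to compound 2 (0.12 log units; within the scatter) for the same change stayed within the scatter. Compound 4 is therefore estimated at 9500 nM, expected to fall between 4000 nM and 22000 nM.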

Compound 4, inhibition constant: 24300 nM
Estimate against measurement, compound 4: 2.6-fold (0.41 log units) below; the measured number lies above the stated range.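

In this assay, methyl in place of hydrogen on the core of compound 3 gives a 2.0-fold higher number from compound 3 to compound 4 (0.29 log units; within the scatter). Set beside the earlier step on the core of compound 1, the change does not separate the two cores: the same change on two cores in this assay, a 1.3-fold lower number (0.12 log units; within the scatter) from compound 1 to compound 2 and a 2.0-fold higher number (0.29 log units; within the scatter) from compound 3 to compound 4, 2.6-fold (0.41 log units) apart, within the scatter of two such steps. Methoxy to ethoxy therefore gives no step beyond the scatter on either core, but this does not show that the two cores respond identically, and two pairs of compounds set no rule for the series.

As far as these compounds go, it remains open whether a longer chain such as butoxy gives a step beyond the scatter on either core. The same question stands for an amine or a carboxylic acid in place of the ethoxy group.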